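This account rests on a few compounds, and the source may have more. Where it says the series, first, only, none or still open, it means among the compounds named here.

Measured compounds:
Compound 1, `O=C1c2ccc(O)c(O)c2C(=O)N1Cc1ccc(F)c(F)c1`, gives 7940 nM in an ADME assay on HOS cells (Homo sapiens) for cytotoxicity; on this read-out lower numbers stand for stronger inhibition and higher numbers for weaker inhibition.
Compound 2, `O=C1c2c(ccc(O)c2O)CN1Cc1ccc(F)c(Cl)c1`, gives 6870 nM in this assay.
Compound 3, `O=C1c2ccc(O)c(O)c2C(=O)N1Cc1ccc(F)c(Cl)c1`, gives 9540 nM in this assay.

All three numbers lie within the usual scatter of one another. Compound 3 differs from compound 1 by chloro in place of fluoro on an aromatic carbon, and that change made a 1.2-fold higher number from compound 1 to compound 3 (0.08 log units; within the scatter). Compound 2 and compound 1 have different cores; the difference between the two cores is not broken down here. The unmeasured compound 4, `O=C1c2c(ccc(O)c2O)CN1Cc1ccc(Cl)c(Cl)c1`, differs from compound 2 by chloro in place of fluoro on an aromatic carbon. This is the same kind of change as from compound 1 to compound 3, but not the same: here the place is ortho to a chloro group and para to a large group, there it was ortho to a fluoro group and meta to a large group. Because the earlier step was a 1.2-fold higher number from compound 1 to compound 3 (0.08 log units; within the scatter), the expected step in this assay is a 1.2-fold higher number from compound 2 to compound 4 (0.08 log units; within the scatter). Compound 4 is therefore estimated at 8200 nM, between 4000 nM and 16000 nM.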

Compound 4, half-maximal inhibitory concentration: 5680 nM
The estimate for compound 4 lay 1.4-fold (0.16 log units) above the measured number; the range from low to high includes it.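

In this assay, putting chloro in place of fluoro on the core of compound 2 gives a 1.2-fold lower number from compound 2 to compound 4 (0.08 log units; within the scatter), a step too small to tell apart from repeat-measurement noise. Set beside the same change on the core of compound 1, the two steps do not differ by more than such noise allows: the same change on two cores in this assay, a 1.2-fold higher number (0.08 log units; within the scatter) from compound 1 to compound 3 and a 1.2-fold lower number (0.08 log units; within the scatter) from compound 2 to compound 4, 1.5-fold (0.16 log units) apart, within the scatter of two such steps. So neither core shows a measurable effect of this change, and nothing here separates the cores, but steps this small cannot show that the change would carry over to other cores or keep the same size.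

Only fluoro and chloro appear at this place on the ring. On these data alone, it remains open whether a larger or differently built group there, such as a methoxy group, an amine or a carboxylic acid, would shift the number beyond the scatter.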